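Cyanophenylamino in place of cyclopropylmethoxy on a quinazoline-like core

The compounds below may be only part of what the source reports. "The series", "measured", "known", "first", "only" and "open" are said of these compounds alone.

Compound 1, `COc1ccc2c(c1)NC(=O)CN2c1nc(NCCCO)nc2ccccc12`, in a functional assay on MDA-MB-231 cells (Homo sapiens) for inhibition, read by sulforhodamine B assay, with a stated time of 48 h (a higher number here means a weaker inhibitor of growth, a lower number a stronger inhibitor of growth), gives 10.2 nM.
Compound 2, `COc1ccc2c(c1)NC(=O)CN2c1nc(Nc2cccc(C#N)c2)nc2ccccc12`, in this assay gives 97.1 nM.
Compound 3, `COc1ccc2c(c1)NC(=O)CN2c1nc(OCC2CC2)nc2ccccc12`, in this assay gives 45.2 nM.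

Compound 3 sits second highest of the three, with compound 2 nearest at a 2.1-fold lower number from compound 2 to compound 3 (0.33 log units; beyond the scatter) and compound 1 furthest at a 4.4-fold higher number from compound 1 to compound 3 (0.65 log units; beyond the scatter). Compound 4, `COc1ccc2c(c1)NC(=O)CN2c1nc(Nc2ccc(C#N)cc2)nc2ccccc12`, has not been measured; it differs from compound 3 in one place: (4-cyanophenyl)amino in place of cyclopropylmethoxy on an aromatic carbon. The step that bears on this is a 2.1-fold lower number from compound 2 to compound 3 (0.33 log units; beyond the scatter), which shows that a cyanophenylamino group on this carbon gave a modestly higher number than cyclopropylmethoxy. Compound 4 is therefore expected to show a modest rise of a 2.0-fold higher number from compound 3 to compound 4 (0.30 log units; within the scatter) in this assay. The estimate for compound 4 is 90 nM, with a range from 35 nM to 250 nM.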

Compound 4, concentration for 50% growth inhibition: 8.31 nM
Beside the measured number, compound 4's estimate is 11-fold (1.03 log units) above it, outside the stated range (below it).
By their numbers in this assay, from the lowest: compounds 4 and 1 (each within the scatter of the next); then compound 3; then compound 2.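

In this assay the position of the nitrile on the phenyl ring proves to matter: a 12-fold lower number from compound 2 to compound 4 (1.07 log units; beyond the scatter) comes with 4-cyanophenyl in place of 3-cyanophenyl. A cyanophenylamino group on this carbon therefore need not raise the number, as a 5.4-fold lower number from compound 3 to compound 4 (0.74 log units; beyond the scatter) follows from (4-cyanophenyl)amino in place of cyclopropylmethoxy. With a 1.2-fold lower number from compound 1 to compound 4 (0.09 log units; within the scatter) this group and the 3-hydroxypropyl chain on the same nitrogen cannot be told apart.

No measurement shown explains these differences. Also open, from the compounds shown here alone, is what a carboxylic acid or an amine in place of the nitrile on the phenyl ring would give.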